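Pentyl for thiophenylethyl on the acylguanidine nitrogen

A few compounds are considered here, and "the series" means these few. Any claim that something is new, unique, unknown or untested is made for them only; others in the source may bear on it.

Three members of the series are measured so far. Compound 1 `Cc1nc(N)sc1CCCN/C(N)=N/C(=O)NCc1ccco1` gives 11.8 nM in a functional assay on Right cardiac atrium for agonist activity at histamine H2 receptor (Cavia porcellus), with a stated time of 30 min, in the presence of a further agent that is not named here; on this read-out lower numbers stand for an effect already at smaller amounts and higher numbers for an effect only at larger amounts of compound. Compound 2 `CCCCCCNC(=O)/N=C(\N)NCCCc1sc(N)nc1C` gives 15.9 nM in this assay, and compound 3 `Cc1nc(N)sc1CCCN/C(N)=N/C(=O)NC(C)c1cccs1` gives 10 nM in this assay. Compound 3 carries the smallest of the three numbers, yet a 1.2-fold lower number from compound 1 to compound 3 (0.07 log units; within the scatter) and a 1.6-fold lower number from compound 2 to compound 3 (0.20 log units; within the scatter) both lie within the scatter, so the three compounds are not separated on this read-out.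

Compound 4 `CCCCCNC(=O)/N=C(\N)NCCCc1sc(N)nc1C` is not yet measured. It differs from compound 3 in one place: pentyl in place of 1-(thiophen-2-yl)ethyl on an amide-type nitrogen. Two of the measured steps bear on this exchange. The closest is the reverse of the step from compound 2 to compound 3, where an open chain stands against the thiophenyl-bearing branched group; that step was a 1.6-fold lower number from compound 2 to compound 3 (0.20 log units; within the scatter). The step of a 1.3-fold higher number from compound 1 to compound 2 (0.13 log units; within the scatter) also swaps an aromatic five-membered ring for a chain on the same nitrogen and is likewise within the scatter. Among the compounds with values here, nothing among the measured compounds points to a shift beyond the scatter when the ring is removed.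

For compound 4 the expected step is therefore a 1.4-fold higher number from compound 3 to compound 4 (0.15 log units; within the scatter), a change not beyond the scatter, with the number for compound 4 estimated at 14 nM in this assay, within a range from 7 nM to 28 nM.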

Compound 4, half-maximal effective concentration: 5.75 nM
The estimate for compound 4 lay 2.4-fold (0.39 log units) above the measured number; measured number below the stated range.
By their numbers in this assay, from the lowest: compounds 4, 3, 1 and 2 (each within the scatter of the next, the first and the last beyond it).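

In this assay, the exchange of 1-(thiophen-2-yl)ethyl for pentyl on the amide-type nitrogen gives a 1.7-fold lower number from compound 3 to compound 4 (0.24 log units; within the scatter), so the ring-bearing group and the open chain remain unseparated on this read-out. What is new is that this position can now show steps beyond the scatter: pentyl in place of hexyl gives a 2.8-fold lower number from compound 2 to compound 4 (0.44 log units; beyond the scatter), a modest step from a change confined to the open chain, and pentylamino in place of the (furan-2-yl)methylamino group gives a 2.1-fold lower number from compound 1 to compound 4 (0.31 log units; beyond the scatter), also modest. Among these four compounds, an aromatic ring on this nitrogen is therefore not required for the lowest numbers, and the two open chains themselves are separated, though only two chains can be compared here.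

As far as these compounds go, whether butyl or heptyl would continue the difference between pentyl and hexyl, and how a terminal amine or carboxylic acid on the pentyl chain would read, remains open. Nothing at hand accounts for the difference between the pentyl and hexyl chains.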